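A few compounds are considered here, and "the series" means these few. Any claim that something is new, unique, unknown or untested is made for them only; others in the source may bear on it.

Working notes on the series. Compound 1 `O=c1cc(CSc2nc3ccccc3s2)oc2ccccc12` gives in a functional assay on SW480 cells (Homo sapiens) for cytotoxicity, read by MTT assay, with a stated time of 72 h (a lower number here means a stronger inhibitor, a higher number a weaker inhibitor), only a limit, > 25000 nM. Compound 2 `Cc1nnc(SCc2coc3ccc(Cl)cc3c2=O)s1` gives in this assay 3200 nM. Compound 3 `Cc1ccc2oc(CSc3nc4nc(C)cc(C)n4n3)cc(=O)c2c1` gives in this assay only a limit, > 25000 nM; it therefore sits at the limit (the limit of > 25000 nM in this assay, at which 2 of the 3 values shown sit), and no ordering against compound 1 is possible from these two limits. The next step leads to compound 4 `Cc1cc(C)n2nc(SCc3cc(=O)c4cc(Cl)ccc4o3)nc2n1`, with chloro in place of methyl on an aromatic carbon. Going by the values given here, no measured pair isolates this change. Compound 2, which carries a chloro on its shared core, and compound 3 differ in more than one place, so their two values only show that the chloro-bearing compound 2 gives a number while compound 3 gives a limit. Compound 4 is expected to reach 9000 nM, with a range of 2500 nM to 25000 nM, meaning an expected step of an at least 2.7-fold lower number from compound 3 to compound 4 (0.44 log units; beyond the scatter) that may still end at the limit.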

Compound 4, half-maximal inhibitory concentration: > 25000 nM
Compound 4 gave a limit, no number (the forecaster's own chance of this, stated with the estimate: 40%); at least 2.7-fold (0.44 log units) between middle value and limit.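

Compound 3 and compound 4 both give only a limit in this assay, so no step can be read for chloro in place of methyl: the limit of > 25000 nM in this assay, at which 3 of the 4 values shown sit. The compounds shown leave open whether this change shifts the read-out at all on the shared core.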